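Bromo-indazole benzylamines: sulfamoyl replaces acetamido

A few compounds are considered here, and "the series" means these few. Any claim that something is new, unique, unknown or untested is made for them only; others in the source may bear on it.

Measured compounds:
compound 1 `Oc1cccc(CNc2cc(Br)cc3[nH]ncc23)c1` — 55%
compound 2 `CC(=O)Nc1ccc(CNc2cc(Br)cc3[nH]ncc23)cc1` — "not active" (no number reported)

In an assay for inhibition of Tryptophan 2,3-dioxygenase (Homo sapiens), with a stated time of 1 h, tested at 10 uM (on this read-out lower numbers stand for less inhibition and higher numbers for more inhibition at the one concentration tested (going by the name of the read-out)), compound 1 gives 55%. Compound 2 is reported as "not active" (no number reported) in this assay, with no single number behind that statement, so compound 2 cannot be placed more precisely against compound 1.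

The step to compound 3 `NS(=O)(=O)c1ccc(CNc2cc(Br)cc3[nH]ncc23)cc1` changes one group: sulfamoyl in place of acetamido on an aromatic carbon. Going by the values given here, no measured pair covers this change, so its size is open; compound 2 has no number in this assay, so no direction can be taken from it.

Compound 3 is expected to read about 15% in this assay, with a range from 0% to 45%, and there is a fair chance it is likewise reported only as not active.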

Compound 3, a percentage reported as inhibition, at one concentration (the size of the read-out at that concentration, not a potency): 75%
Compound 3: middle estimate off by 60 percentage points, on the low side; measured number above the stated range.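

No new step can be read: compound 2 carries no number in this assay, so compound 3 at 75% has no measured partner. The compounds shown leave open how large the change from acetamido to sulfamoyl is. Nothing available accounts for the result.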